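Half-life notes: tert-butyl to sec-butyl

The compounds below may be only part of what the source reports. "The series", "measured", "known", "first", "only" and "open" are said of these compounds alone.

compound 1 `COc1cnc(O[C@@H]2C[C@@H](C(=O)N[C@]3(C(=O)NS(=O)(=O)C4CC4)C[C@H]3C3CC3)N(C(=O)[C@@H](NC(=O)OC(C)(C)C(F)F)C(C)(C)C)C2)c2cc(Cl)ccc12`: 2 h
compound 2 `COc1cnc(O[C@@H]2C[C@@H](C(=O)N[C@]3(C(=O)NS(=O)(=O)C4CC4)C[C@H]3C3CC3)N(C(=O)[C@@H](NC(=O)O[C@H](C)C(F)(F)F)C(C)(C)C)C2)c2cc(Cl)ccc12`: 2.12 h
compound 3 `COc1cnc(O[C@@H]2C[C@@H](C(=O)N[C@]3(C(=O)NS(=O)(=O)C4CC4)C[C@H]3C3CC3)N(C(=O)[C@@H](NC(=O)O[C@H](C)C(F)(F)F)C(C)(C)C)C2)c2cc(Cl)cc(Cl)c12`: 2 h

In an ADME assay on liver (Homo sapiens) for metabolic stability, using microsomes (a higher number here means that the compound lasts longer, a lower number that the compound disappears faster), all three values lie within the scatter of one another, and compound 2 at 2.12 h stands level with the other two. Compound 4 `CC[C@@H](C)[C@H](NC(=O)O[C@H](C)C(F)(F)F)C(=O)N1C[C@H](Oc2ncc(OC)c3ccc(Cl)cc23)C[C@H]1C(=O)N[C@]1(C(=O)NS(=O)(=O)C2CC2)C[C@H]1C1CC1` differs from compound 2 at one place: sec-butyl in place of tert-butyl on a saturated chain carbon bound to an amide-type nitrogen and a carbonyl carbon. The two have the same atoms, joined differently.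

Two measured steps are available. 1-(Trifluoromethyl)ethyl in place of 1-(difluoromethyl)-1-methylethyl gave a 1.1-fold higher number from compound 1 to compound 2 (0.03 log units; within the scatter), and chloro in place of hydrogen gave a 1.1-fold lower number from compound 2 to compound 3 (0.03 log units; within the scatter). Both lie within the scatter. Neither touches the tert-butyl group, so they bear on this change only indirectly, and the data hold no measured replacement of that group.

With only these small steps to go on, no shift beyond the scatter is expected in this assay. The expected change is a 1.2-fold lower number from compound 2 to compound 4 (0.07 log units; within the scatter). The estimate for compound 4 is 1.8 h, with an expected range of 1 h to 3.2 h.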

Compound 4, half-life: 1.63 h
Compound 4: middle estimate off by 1.1-fold (0.04 log units), on the high side; low and high end bracket the measured number.
By their numbers in this assay, from the lowest: compounds 4, 1, 3 and 2 (each within the scatter of the next).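

In this assay, sec-butyl in place of tert-butyl on a saturated chain carbon bound to an amide-type nitrogen and a carbonyl carbon gives a 1.3-fold lower number from compound 2 to compound 4 (0.11 log units; within the scatter), the only reading at this place among the compounds shown. The earlier steps shown here concerned other places, whereas this one shows that rearranging these four carbons and adding one defined stereocentre moves the half-life no further than the scatter. No supporting measurement bears on why the step is this small.

Still open, as far as these compounds go, is how a longer chain, a cyclopropyl group or an amine at this place would read in this assay. Also open, from the compounds shown here alone, are the opposite configuration at the new sec-butyl stereocentre and whether the replacement reads the same alongside the added chloro of compound 3.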